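From Compound 3 to Compound 4: An Expected Estimate

This account rests on a few compounds, and the source may have more. Where it says the series, first, only, none or still open, it means among the compounds named here.

Of the compounds shown here, three sharing one core have been measured in an in vitro assay on BTI-TN-5B1-4 cells for inhibition of Amine oxidase [flavin-containing] A (Homo sapiens), read by fluorescence; on this read-out higher numbers stand for weaker inhibition and lower numbers for stronger inhibition. Compound 1 `CCOC(=O)c1ccc(NC(=O)c2cc3ccccc3oc2=O)cc1` gives 16000 nM, compound 2 `CSc1ccc(NC(=O)c2cc3ccccc3oc2=O)cc1` gives 14800 nM, and compound 3 `O=C(Cl)c1ccc(NC(=O)c2cc3ccccc3oc2=O)cc1` gives 9670 nM. The single-point changes among them moved the read-out only a little: a 1.1-fold lower number from compound 1 to compound 2 (0.03 log units; within the scatter), a 1.7-fold lower number from compound 1 to compound 3 (0.22 log units; within the scatter) and a 1.5-fold lower number from compound 2 to compound 3 (0.18 log units; within the scatter). Compound 3 is therefore not separated from either neighbour beyond the scatter, and the whole set behaves as one cluster.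

Compound 4 `CS(=O)(=O)c1ccc(NC(=O)c2cc3ccccc3oc2=O)cc1` is the next variant. Its change from compound 3 is a group of 4 heavy atoms (1 carbon, 2 oxygen, 1 sulfur; no ring) in place of a group of 3 heavy atoms (1 carbon, 1 oxygen, 1 chlorine; no ring), on an aromatic carbon; the new group sits on the six-membered carbon-only aromatic ring, para to a large group, where the three earlier groups also sat. Within the data shown here, the steps that bear on it are exactly those three, since each replaced one group at this same position with another, and each stayed within the scatter. Nothing in the data shows this position to be sensitive to the group placed on it, and no pattern beyond that can be claimed from three compounds.

Compound 4 is thus expected to give 12000 nM in this assay, with a likely range from 5000 nM to 30000 nM, and the expected step of a 1.2-fold higher number from compound 3 to compound 4 (0.09 log units; within the scatter) lies within the scatter.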

Compound 4, half-maximal inhibitory concentration: 9330 nM
For compound 4 the middle estimate is 1.3-fold (0.11 log units) above the measured one, and the stated range covers the measured number.
By their numbers in this assay, from the lowest: compounds 4, 3, 2 and 1 (each within the scatter of the next).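

In this assay methylsulfonyl on this aromatic carbon, para to a large group, does not separate from any of the three groups measured there before: the read-out shows a 1.0-fold lower number from compound 3 to compound 4 (0.02 log units; within the scatter) and a 1.6-fold lower number from compound 2 to compound 4 (0.20 log units; within the scatter) and also a 1.7-fold lower number from compound 1 to compound 4 (0.23 log units; within the scatter) in the comparison with the ethoxycarbonyl compound. Among these compounds, the second of these steps adds a pairing the earlier compounds did not offer, methylsulfanyl against methylsulfonyl, two closely related sulfur groups that this read-out cannot tell apart. With four different groups now in one cluster, the position still shows no sensitivity to the group placed on it, and no measurement shown here accounts for that flatness.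

From the compounds shown here alone, what an amine, a carboxylic acid or a longer chain would do at this position stays open, so these four compounds cannot show whether any group there moves the number beyond the scatter. All four also share the same core and the same amide link, which leaves open whether a change elsewhere in the molecule would matter more than any change made here.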